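Trimming a cyclopropyl from the amine side chain

This account rests on a few compounds, and the source may have more. Where it says the series, first, only, none or still open, it means among the compounds named here.

Measured so far:
compound 1, `c1cnc2c(c1)CCC[C@@H]2N(CC1CC1)C[C@H]1Cc2c(cccc2N2CCNCC2)CN1`: 82.1%
compound 2, `CN(C[C@H]1Cc2c(cccc2N2CCN(C3COC3)CC2)CN1)[C@H]1CCCc2cccnc21`: 83.1%
compound 3, `CN(C[C@H]1Cc2c(cccc2N2CCN(Cc3ccccn3)CC2)CN1)[C@H]1CCCc2cccnc21`: 4.2%

Compound 1 stands second highest of the three numbers in an ADME assay on microsomes from liver (Homo sapiens) for metabolic stability, read by LC-MS, with a stated time of 10 min; on this read-out lower numbers stand for a less stable compound and higher numbers for a more stable compound. Compound 2 lies within the scatter of it, so the two cannot be told apart; compound 3 lies far lower, beyond the scatter. Among the measured compounds shown here, the one measured step between neighbours concerns the ring amine of the shared core: a number 78.9 percentage points lower from compound 2 to compound 3 (beyond the scatter).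

The unmeasured compound 4, `CN(C[C@H]1Cc2c(cccc2N2CCNCC2)CN1)[C@H]1CCCc2cccnc21`, differs from compound 1 at another site. The change is hydrogen in place of cyclopropyl on a saturated chain carbon bound to an amine nitrogen; cut one bond further out, it reads cyclopropylmethyl to methyl. For the measured compounds named here, no measured step touches this position, so the step from compound 2 to compound 3 does not bear on it directly. What the data do show is that compound 2, which carries the methyl rather than the cyclopropylmethyl, gives 83.1% in this assay, a number within the scatter of compound 1. On that basis compound 4 is expected to stay close to compound 1, with a step of a number 0.9 percentage points higher from compound 1 to compound 4 (within the scatter), not beyond the scatter. The estimate for compound 4 in this assay is 83%, within a range of 66% to 95%.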

Compound 4, percent of the compound remaining: 99.7%
Beside the measured number, compound 4's estimate is 16.7 percentage points below it, outside the stated range (above it).
By their numbers in this assay, from the lowest: compound 3; then compounds 1 and 2 (each within the scatter of the next); then compound 4.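

Among the compounds shown here, the cyclopropylmethyl position proves not to be silent: in this assay, trimming that group to methyl gives a number 17.6 percentage points higher from compound 1 to compound 4 (beyond the scatter), a step beyond the scatter that no earlier pair could show. For the compounds shown here, compound 4 also brings the first reading of hydrogen on the amine nitrogen in a ring, and that change gives a number 16.6 percentage points higher from compound 2 to compound 4 (beyond the scatter) when it replaces oxetan-3-yl and a number 95.5 percentage points higher from compound 3 to compound 4 (beyond the scatter) when it replaces (pyridin-2-yl)methyl, so compound 4 stands highest of the four, with each of its steps beyond the scatter. Nothing among the data shown explains why either site moves the number in this way.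

The compounds shown leave open how an ethyl or a propyl group would read on the amine nitrogen, and so whether the number follows the length of that chain or depends on the cyclopropyl ring itself. They also leave open where an acetyl or a plain methyl group on the amine nitrogen in a ring would fall in the wide span from compound 3 to compound 4.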